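Swapping a bromo for a cyano: what the lipophilicity may do

A few compounds are considered here, and "the series" means these few. Any claim that something is new, unique, unknown or untested is made for them only; others in the source may bear on it.

Measured so far, each in a physicochemical assay for lipophilicity; a higher number here means a more lipophilic compound, a lower number a more polar compound:
- compound 1, `O=C(CCC1=CCN(Cc2ccc(F)cc2)C1=O)NO`, gives 0.571
- compound 2, `O=C(CCC1=CCN(Cc2ccc(Br)cc2)C1=O)NO`, gives 1.26
- compound 3, `O=C(CCC1=CCN(CCCCc2ccc(Cl)cc2)C1=O)NO`, gives 2.17

Compound 2 sits second highest of these three numbers. Within the data shown here, its nearest neighbour is compound 1, which lies lower, and the two values differ by more than the scatter; compound 3 is the furthest, with a higher value, and here no single-point step is available, so only the two numbers themselves can be compared.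

The next compound, compound 4, is `N#Cc1ccc(CN2CC=C(CCC(=O)NO)C2=O)cc1`. Its difference from compound 2 is cyano in place of bromo on an aromatic carbon

Among the measured compounds shown here, one measured step bears on this: a number 0.69 log units higher from compound 1 to compound 2 (beyond the scatter). Bromo thus raised the number over fluoro by a modest amount. Cyano carries a hydrogen-bond acceptor where bromo carries none, so the step in this assay is expected to run the other way, downward from compound 2, and to be larger than the modest rise seen from fluoro to bromo, landing below compound 1.

Compound 4 is therefore expected to give -0.15 in this assay, with a likely range from -0.7 to 0.4. The estimated step is a number 1.41 log units lower from compound 2 to compound 4 (beyond the scatter).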

Compound 4, distribution coefficient: 0.197
For compound 4 the middle estimate is 0.35 log units below the measured one; the range from low to high includes it.
By their numbers in this assay, from the lowest: compound 4; then compound 1; then compound 2; then compound 3.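

Among these compounds, at the position para to a large group on the aromatic ring, the two earlier compounds carried only halogens, and cyano is the first group there with a hydrogen-bond acceptor; in this assay this change gives a number 1.06 log units lower from compound 2 to compound 4 (beyond the scatter), a step labelled large where the step from fluoro to bromo was modest. Cyano also falls short of fluoro, with a number 0.37 log units lower from compound 1 to compound 4 (beyond the scatter), so the three groups at this position now stand in a clear order, with cyano lowest, fluoro in the middle and bromo highest, each separated by more than the scatter. No measurement shown here explains why the number falls with cyano, so the drop stands as an observation about these compounds only.

From the compounds shown here alone, it remains open where an amine, a carboxylic acid or a trifluoromethyl group at this same position would fall relative to these three. Compound 3 differs from the others in both its chain and its halogen, so steps to it cannot be read, and the separate contribution of a longer chain stays unresolved.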